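The source may report more compounds than this note shows. Statements on the series, on what has been measured and on what is new or still open speak of the compounds shown alone.

In an assay on isolated protein for displacement of a labelled ligand from melanin-concentrating hormone receptor 1 (Homo sapiens) (on this read-out higher numbers stand for weaker inhibition and lower numbers for stronger inhibition), compound 1 `CC(C)(C)c1cc(N)c2cc(NC(=O)/C=C/c3ccc(C(F)(F)F)cc3)ccc2n1` gives 0.3 nM. Compound 2 `Nc1cc(C2CCC2)nc2ccc(NC(=O)/C=C/c3ccc(C(F)(F)F)cc3)cc12` gives 2 nM and compound 3 `Nc1cc(C2CCCCC2)nc2ccc(NC(=O)/C=C/c3ccc(C(F)(F)F)cc3)cc12` gives 1.2 nM. Compound 3 therefore carries the second highest number of the three: it lies within the scatter of compound 2, while against compound 1 there is a 4.0-fold higher number from compound 1 to compound 3 (0.60 log units; beyond the scatter), a modest step that is beyond the scatter. Compound 4 `Cc1cc(N)c2cc(NC(=O)/C=C/c3ccc(C(F)(F)F)cc3)ccc2n1` varies the same aromatic carbon once more, with methyl in place of cyclohexyl on an aromatic carbon. The measured steps that bear on this carbon are a 6.7-fold higher number from compound 1 to compound 2 (0.82 log units; beyond the scatter) and a 4.0-fold higher number from compound 1 to compound 3 (0.60 log units; beyond the scatter), both modest and both beyond the scatter, whereas a 1.7-fold lower number from compound 2 to compound 3 (0.22 log units; within the scatter) stays within the scatter, so the two ring-bearing compounds cannot be told apart. Going by the values given here, exchanging tert-butyl for either ring raised the number modestly, and a methyl group, the smallest group to sit here, has no measured counterpart. The expectation is that compound 4 lands near the ring-bearing compounds or somewhat higher, with a step of modest size at most in this assay. The expected step is a 2.5-fold higher number from compound 3 to compound 4 (0.40 log units; beyond the scatter). Compound 4 is accordingly estimated at 3 nM in this assay, with a range from 0.8 nM to 12 nM.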

Compound 4, half-maximal inhibitory concentration: 8 nM
Compound 4: the middle estimate sits 2.7-fold (0.43 log units) below what was measured; low and high end bracket the measured number.
By their numbers in this assay, from the lowest: compound 1; then compounds 3 and 2 (each within the scatter of the next); then compound 4.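

Going by these compounds alone, compound 4 shows that this aromatic carbon, next to the ring nitrogen, is more sensitive to the group it carries than the earlier compounds showed, since tert-butyl, cyclobutyl and cyclohexyl had differed only modestly or within the scatter in this assay. Methyl gives the first large step at this position, a 27-fold higher number from compound 1 to compound 4 (1.43 log units; beyond the scatter), and it also stands apart from both ring-bearing compounds, with a 4.0-fold higher number from compound 2 to compound 4 (0.60 log units; beyond the scatter) and a 6.7-fold higher number from compound 3 to compound 4 (0.82 log units; beyond the scatter), so exchanging either ring for methyl costs more than exchanging tert-butyl for either ring did. No evidence at hand accounts for this loss of inhibition, and the four compounds rank only the groups themselves.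

The compounds shown leave open whether the number climbs gradually or abruptly between tert-butyl and methyl, which ethyl or isopropyl at this carbon could help to settle. They also leave open how this position would respond to a group containing a heteroatom, such as a methoxy group or an amine, since all four groups compared here consist of carbon and hydrogen alone.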